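The source may hold more compounds than are shown below. What is called first, only, known or untested is meant among the compounds shown, and "the series" means these compounds.

Of the compounds shown here, three of one macrocyclic family have been tested in a functional assay on SMMC-7721 cells (Homo sapiens) for antiproliferative activity, read by MTT assay, with a stated time of 48 h; a lower number here means a stronger inhibitor, a higher number a weaker inhibitor. Compound 1 `C=C1/C=C/C(=O)/C(CO)=C\C[C@](C)(CCC=C(C)C)/C=C/[C@H]1OC(=O)C=C(C)C` gives 4300 nM in this assay. For compound 2 `CC(C)=CCC[C@]1(C)/C=C/[C@@H](OC(=O)C=C(C)C)[C@](C)(O)/C=C/C(=O)/C(C(=O)O)=C\C1` the result in this assay is only a limit, > 10000 nM, and not a number (the limit of > 10000 nM in this assay, at which 1 of the 3 values shown sits). For compound 3 `CC(C)=CCC[C@]1(C)/C=C/[C@@H](OC(=O)C=C(C)C)[C@](C)(O)CCC(=O)/C(CO)=C\C1` the outcome in this assay is likewise a limit, > 40000 nM (the limit of > 40000 nM in this assay, at which 1 of the 3 values shown sits). Compound 2 therefore stands at a limit, with one further limit among the three values shown, while compound 1 alone returns a number. Within the data shown here, no step between two measured compounds that differ in a single place can be drawn from these three.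

Compound 4 `CO/N=C/C1=C/C[C@](C)(CCC=C(C)C)/C=C/[C@@H](OC(=O)C=C(C)C)[C@](C)(O)/C=C/C1=O` is not yet measured. It differs from compound 2 in one place: a group of 4 heavy atoms (2 carbon, 1 nitrogen, 1 oxygen; no ring) in place of a group of 3 heavy atoms (1 carbon, 2 oxygen; no ring), on a double-bonded ring carbon. Among the measured compounds shown here, no measured step is available to lean on. The step from compound 2 to compound 4 is expected to be a modest gain in potency, an at least 1.2-fold lower number from compound 2 to compound 4 (0.09 log units; that floor lies within the scatter), though a result that is again a limit remains quite possible. Compound 4 is expected to give about 8000 nM in this assay, within a range from 2000 nM to 30000 nM.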

Compound 4, half-maximal inhibitory concentration: 3470 nM
For compound 4 the middle estimate is 2.3-fold (0.36 log units) above the measured one; the range from low to high includes it.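

Among these compounds, with carboxy on the double-bonded ring carbon, compound 2 returned only a limit in this assay, so the earlier compounds gave no measured view of any change at this place. Putting the group of 4 heavy atoms, which has 0 hydrogen-bond donors and 2 hydrogen-bond acceptors, in place of carboxy gives an at least 2.8-fold lower number from compound 2 to compound 4 (0.45 log units; beyond the scatter), which shows that activity in this assay responds to the group held at this ring carbon. That step is only a floor, and its full size cannot be read: the limit of > 10000 nM in this assay, at which 1 of the 4 values shown sits.

From the compounds shown here alone, what a methyl ester or an amide would do on this ring carbon stays open. So does the question of whether the gain comes from the loss of carboxy or from the entering group itself.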